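Series notes: hydroxy for methoxycarbonyl on compound 1

A few compounds are considered here, and "the series" means these few. Any claim that something is new, unique, unknown or untested is made for them only; others in the source may bear on it.

Three compounds of the shared core have a number or a limit in an ADME assay on DU-145 cells (Homo sapiens) for cytotoxicity, read by MTT assay, with a stated time of 72 h; on this read-out higher numbers stand for weaker inhibition and lower numbers for stronger inhibition. Compound 1 `COC(=O)c1cc(C2=C(c3cc(OC)c(OC)c(OC)c3)C(=O)CC2O[SiH2]C(C)(C)C)ccc1OC` reaches only a limit of the assay: in this assay compound 1 gives > 100 ug/mL. Compound 2 `COc1cc(C2=C(c3cc(C)c(OC)c(C)c3)C(O)CC2=O)cc(OC)c1OC` also sits at a limit: in this assay compound 2 gives > 100 ug/mL. Among the measured compounds shown here, compound 3 `COc1ccc(C2=C(c3cc(OC)c(OC)c(OC)c3)C(=O)CC2O)cc1` is the one compound with a number: in this assay compound 3 gives 18.7 ug/mL. On the numbers shown, compound 1 therefore stands at the limit of > 100 ug/mL in this assay, at which 2 of the 3 values shown sit, together with compound 2, and no step between two measured compounds is available to gauge the size of any change.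

Compound 4 `COc1ccc(C2=C(c3cc(OC)c(OC)c(OC)c3)C(=O)CC2O[SiH2]C(C)(C)C)cc1O` is not yet measured in this assay. It differs from compound 1 at one place: hydroxy in place of methoxycarbonyl on an aromatic carbon. The tert-butyl silyl ether on the core of compound 1 is kept in compound 4.

For the measured compounds named here, with compound 1 at a limit and compound 3 the only compound showing a number, the step expected from compound 1 to compound 4 in this assay is an at least 1.4-fold lower number from compound 1 to compound 4 (0.15 log units; that floor lies within the scatter), a modest move toward stronger inhibition that may not carry beyond the scatter. The expected value for compound 4 in this assay is estimated at 70 ug/mL, within 20 ug/mL to 200 ug/mL, with a real chance that only a limit is again reported.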

Compound 4, half-maximal inhibitory concentration: 75 ug/mL
The estimate for compound 4 lay 1.1-fold (0.03 log units) below the measured number, within the range that was stated.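

In this assay, among the compounds shown here, the change from 4-methoxy-3-(methoxycarbonyl)phenyl to 3-hydroxy-4-methoxyphenyl gives the one step that can be read: an at least 1.3-fold lower number from compound 1 to compound 4 (0.12 log units; that floor lies within the scatter). For the compounds shown here, with the tert-butyl silyl ether kept, hydroxy in place of methoxycarbonyl on this aromatic carbon, ortho to a methoxy group, gives compound 4 a measured number, so this position can now be assessed by a change in one place; compound 3, the only earlier compound with a number, differs from compound 1 in more than one place. The value for compound 1 is only a limit of the assay, so the step gives a floor, that floor alone does not separate the change from the scatter, and the true size of the change remains unknown: the limit of > 100 ug/mL in this assay, at which 2 of the 4 values shown sit.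

The compounds shown leave open whether an amine or a carboxylic acid on this aromatic carbon would give a lower or a higher number than hydroxy in this assay. They also leave open whether the same exchange would read the same way on a core that carries a free hydroxy in place of the tert-butyl silyl ether.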